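Trifluoromethyl in Place of Chloro on the Shared Core

This account rests on a few compounds, and the source may have more. Where it says the series, first, only, none or still open, it means among the compounds named here.

Compound 3 `C#C[C@@]1(O)[C@@H](CO)O[C@@H](n2cc(Cl)c3c(N)ncnc32)[C@@H]1O` gives 51 nM in a functional assay on HeLa cells (Homo sapiens) for antiproliferative activity, read by cell counting, with a stated time of 72 h (on this read-out higher numbers stand for weaker inhibition and lower numbers for stronger inhibition), the lowest of the two numbers available. Compound 2 `C#C[C@@]1(O)[C@@H](CO)O[C@@H](n2cnc3c(-c4ccc(F)cc4)ncnc32)[C@@H]1O` gives 220000 nM in this assay. Compound 1 `C#C[C@@]1(O)[C@@H](CO)O[C@@H](n2cnc3c(-c4ccc(OC)cc4)ncnc32)[C@@H]1O` is reported only as a limit of this assay, > 250000 nM, and the limit of > 250000 nM in this assay, at which 1 of the 3 values shown sits, confirms that one value sits there. Among the compounds with values here, the one measured step, an at least 1.1-fold lower number from compound 1 to compound 2 (0.05 log units; that floor lies within the scatter), concerns a group on a different ring of the shared core and does not touch the position changed here.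

Compound 4 `C#C[C@@]1(O)[C@@H](CO)O[C@@H](n2cc(C(F)(F)F)c3c(N)ncnc32)[C@@H]1O` differs from compound 3 in one place: trifluoromethyl in place of chloro on an aromatic carbon. Within the data shown here, no measured step bears on this exchange, so the expectation rests on compound 3 alone, and the change is expected to stay within the scatter, with a 1.2-fold higher number from compound 3 to compound 4 (0.07 log units; within the scatter) as the estimated step in this assay. Compound 4 is therefore expected to give about 60 nM in this assay, between 15 nM and 250 nM.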

Compound 4, half-maximal inhibitory concentration: 750 nM
Beside the measured number, compound 4's estimate is 13-fold (1.10 log units) below it, outside the stated range (above it).
By their numbers in this assay, from the lowest: compound 3; then compound 4; then compound 2. At a limit, above all of these: compound 1.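

This position is not indifferent to what sits on it: in this assay, trifluoromethyl in place of chloro gives a 15-fold higher number from compound 3 to compound 4 (1.17 log units; beyond the scatter). Within the data shown here, the earlier compounds showed only a change on a different ring of the shared core, so this is the first measured sign that activity depends on the group on this aromatic carbon, and chloro is the better of the two groups compared here. The exchange swaps one heavy atom for four, with no hydrogen-bond donors or acceptors on either side, but nothing shown here establishes why the number rises.

Going by these compounds, it stays open how a bromo, a methyl, a nitrile or an amine on this carbon would compare with chloro. Also open, on these data alone, is whether the same exchange would produce a step of similar size with a different group elsewhere on the shared core.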